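Difluoroethyl in Place of Cyclopropyl on the Shared Core

The source may hold more compounds than are shown below. What is called first, only, known or untested is meant among the compounds shown, and "the series" means these compounds.

Compound 2 `Cc1cc(Nc2ccc(S(F)(F)(F)(F)F)cc2)n2nc(C3CC3)nc2n1` is reported in an in vitro ADME assay on microsomes from liver (Homo sapiens) for metabolic stability (on this read-out lower numbers stand for slow clearance and higher numbers for fast clearance), only as a limit, < 5 mL.min-1.g-1. That reading is the limit of < 5 mL.min-1.g-1 in this assay, at which 2 of the 3 values shown sit. Compound 3 `Cc1cc(Nc2ccc(C(F)(F)F)cc2)n2nc(C3CC3)nc2n1` likewise gives only a limit in this assay, < 5 mL.min-1.g-1. The step that the two limits leave unreadable from compound 2 to compound 3 therefore cannot be sized. Among the measured compounds shown here, compound 1 `CCc1nc2nc(C)cc(Nc3cccc(Cl)c3)n2n1`, the one compound of the set with a numerical result, gives 78.3 mL.min-1.g-1 in this assay.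

Compound 4 `Cc1cc(Nc2ccc(S(F)(F)(F)(F)F)cc2)n2nc(C(C)(F)F)nc2n1` differs from compound 2 by 1,1-difluoroethyl in place of cyclopropyl on an aromatic carbon. For the measured compounds named here, no measured step involves this change; the only measured step is the one from compound 2 to compound 3, which is unreadable, so the data give no basis for expecting a step beyond the scatter in either direction. Since compound 2 stands at the limit, compound 4 is expected to stand near that same limit, estimated at 5 mL.min-1.g-1, with a range from 2 mL.min-1.g-1 to 15 mL.min-1.g-1. The step of a number no lower from compound 2 to compound 4 (the limit leaves the size open) is expected to be small and may well remain hidden by the limit.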

Compound 4, intrinsic clearance in microsomes: < 5 mL.min-1.g-1
Compound 4 was reported as a limit; the forecaster's own chance of this, stated with the estimate: 50%; the middle value sits exactly at the limit.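

Compound 4, like compound 2, is reported in this assay only as a limit, so no step between the two can be read: the limit of < 5 mL.min-1.g-1 in this assay, at which 3 of the 4 values shown sit.

The compounds shown leave open how far apart compound 2 and compound 4 lie, and so how 1,1-difluoroethyl compares with cyclopropyl on the shared core.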